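The source may report more compounds than this note shows. Statements on the series, on what has been measured and on what is new or still open speak of the compounds shown alone.

Measured in a functional assay on PC-3 cells (Homo sapiens) for cytotoxicity, read by MTT assay; a lower number here means a stronger inhibitor, a higher number a weaker inhibitor:
Compound 1 `Cc1cccc(Nc2nc(C)c(C(=O)/C=C/c3ccccc3Cl)s2)c1` gives 22200 nM.
Compound 2 `Cc1nc(Nc2cccc(Cl)c2)sc1C(=O)/C=C/c1ccc(Cl)cc1` gives > 25000 nM; this is a limit of the assay, not a number.
Compound 3 `Cc1cccc(Nc2nc(C)c(C(=O)/C=C/c3ccccc3)s2)c1` gives 11700 nM.

Compound 4 `Cc1nc(Nc2ccc(Cl)c(Cl)c2)sc1C(=O)/C=C/c1ccc(Cl)cc1` has not yet been measured in this assay. Compounds 1 and 3 share one core. Compound 2 differs from compound 3 in more than one place, and the difference between the two cores is not broken down here.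

Compound 4 arises from compound 2 by chloro in place of hydrogen on an aromatic carbon. Compound 1 arises from compound 3 by the same kind of change, (chloro in place of hydrogen on an aromatic carbon). The surroundings are not the same: in compound 4 the entering chloro sits ortho to a chloro group and para to a large group, in compound 1 it sits ortho to a large group. The measured step of this kind is a 1.9-fold higher number from compound 3 to compound 1 (0.28 log units; within the scatter).

For compound 2 only a limit is known, namely (the limit of > 25000 nM in this assay, at which 1 of the 3 values shown sits), so no numerical step can be read from it, and the same is true of any step that starts from it. The step from compound 2 to compound 4 is expected to be about a step that the limit leaves unreadable from compound 2 to compound 4, which rests on the earlier step of a 1.9-fold higher number from compound 3 to compound 1 (0.28 log units; within the scatter) lying within the scatter. Compound 4 is therefore expected near 30000 nM. The expected range for compound 4 runs from 12000 nM to 80000 nM, and it is more likely than not that compound 4 is again reported only as a limit.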

Compound 4, half-maximal inhibitory concentration: > 25000 nM
Compound 4: no number, only a limit (the forecaster's own chance of this, stated with the estimate: 65%); the middle value lies beyond the limit too.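

In this assay, compound 2 and compound 4 are both reported only as limits, so no step between them can be read: the limit of > 25000 nM in this assay, at which 2 of the 4 values shown sit.

The compounds shown leave open whether the change from 3-chlorophenyl to 3,4-dichlorophenyl shifts the number at all, and how far the true values of compound 2 and compound 4 lie past that limit.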